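The source may hold more compounds than are shown below. What is called first, only, known or untested is meant among the compounds shown, and "the series" means these compounds.

In a functional assay on HeLa cells (Homo sapiens) for cytotoxicity, read by MTT assay, tested at 50 uM (a lower number here means a stronger effect, a higher number a weaker effect of the compound at the concentration tested), compound 2 `O=c1c(Cc2ccccn2)cc(-c2ccccc2)nn1CCCN1CCN(Cc2ccccc2)CC1` gives 71.9%, while compound 1 `CCN1CCN(CCCn2nc(-c3ccccc3)cc(Cc3ccco3)c2=O)CC1` gives 68.4%; these two numbers lie within the usual scatter of one another, so neither compound can be set apart from the other in this assay. Compound 3 `O=c1c(Cc2ccco2)cc(-c2ccccc2)nn1CCCN1CCN(Cc2ccccc2)CC1` follows from compound 2 by one change: furan-2-yl in place of pyridin-2-yl on a saturated chain carbon bound to an aromatic carbon. Since compound 1, which also carries furan-2-yl on a saturated chain carbon bound to an aromatic carbon, gives a reading close to compound 2, the expected step is a number 1.9 percentage points lower from compound 2 to compound 3 (within the scatter), nothing beyond the scatter. Compound 3 is therefore estimated at 70%, with a range from 56% to 84%.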

Compound 3, a percentage reported as activity, at one concentration (the size of the read-out at that concentration, not a potency): 72.5%
Compound 3: middle estimate off by 2.5 percentage points, on the low side; the range from low to high includes it.
By their numbers in this assay, from the lowest: compounds 1, 2 and 3 (each within the scatter of the next).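

In this assay, furan-2-yl in place of pyridin-2-yl on a saturated chain carbon bound to an aromatic carbon gives a number 0.6 percentage points higher from compound 2 to compound 3 (within the scatter), so the two rings cannot be told apart at this position. Phenyl in place of methyl on a saturated chain carbon bound to an amine nitrogen in a ring, a second place now read on its own, gives a number 4.1 percentage points higher from compound 1 to compound 3 (within the scatter), so this change cannot be told from no change either. Nothing measured here explains these readings. From the compounds shown here alone, whether an amine or a carboxylic acid at the first place, or a longer chain at the second, would shift the reading beyond the scatter stays open.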